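This account rests on a few compounds, and the source may have more. Where it says the series, first, only, none or still open, it means among the compounds named here.

Measured so far in a functional assay on MDA-MB-231 cells (Homo sapiens), read by wound healing assay, with a stated time of 24 h; a higher number here means a weaker inhibitor, a lower number a stronger inhibitor:

Compound 1 `CCn1c(C(=O)OCCc2ccc(O)cc2)cc(=O)c2ccc(C)nc21`: > 100000 nM
Compound 2 `O=C(NCc1ccccc1)OCCc1ccc(O)cc1`: > 100000 nM

In this assay, compound 2 gives > 100000 nM, which is a limit of the assay and not a number. Compound 1 also gives only a limit, > 100000 nM. The data so far therefore show only (the limit of > 100000 nM in this assay, at which 2 of the 2 values shown sit), and neither compound has a measured strength to compare.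

Compound 3 `O=C(NCc1ccccc1)OCCc1ccc(OC(=O)NCc2ccccc2)cc1` comes from compound 2 through a single structural change: benzylcarbamoyl in place of hydrogen on an oxygen on an aromatic ring. Going by the values given here, no measured pair shows what this change does.

The expectation rests mainly on compound 2, whose limit of > 100000 nM gives no exact starting point, so it remains loose. The expected step in this assay is an at least 2.0-fold lower number from compound 2 to compound 3 (0.30 log units; that floor lies within the scatter), a modest move towards stronger inhibition, although another result at the limit would be quite possible. For compound 3 the estimate is 50000 nM, with an expected range from 8000 nM to 100000 nM.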

Compound 3, half-maximal inhibitory concentration: > 100000 nM
Compound 3: no number, only a limit; the forecaster's own chance of this, stated with the estimate: 55%; middle value at least 2.0-fold (0.30 log units) away from the limit.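

In this assay compound 3 gives > 100000 nM, which is a limit of the assay and not a number. Compound 2 also gives only a limit, so the step between compound 2 and compound 3 cannot be read: the limit of > 100000 nM in this assay, at which 3 of the 3 values shown sit.

The compounds shown leave open what structure, if any, would give a measurable strength in this assay.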